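Series notes: three measured compounds, one awaited

The source may report more compounds than this note shows. Statements on the series, on what has been measured and on what is new or still open speak of the compounds shown alone.

Three compounds of the set have been run in an ADME assay on microsomes from liver (Homo sapiens) for metabolic stability, read by LC-MS, using NADPH, with stated times of 10 min and 30 min; on this read-out lower numbers stand for slow clearance and higher numbers for fast clearance. Compound 1 `CCC(=O)N[C@@H]1CCCc2c1cncc2N1C(=O)c2ccc(Cl)cc2[C@@H]1C` has been measured there; its value, < 3.5 mL/min/kg, is a limit of the assay and not a number. Compound 2 `CC[C@@H]1c2cc(Cl)ccc2C(=O)N1c1cncc2c1CCC[C@H]2NC(C)=O` gives < 3.5 mL/min/kg in this assay, again a limit rather than a measured number. Compound 3 `CCC(=O)N[C@@H]1CCCc2c1cncc2N1C(=O)c2ccc(Cl)cc2[C@@H]1CC` gives < 3.5 mL/min/kg in this assay, also a limit.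

Within the measured trio one single change can be traced. From compound 3 to compound 1 the change is hydrogen in place of methyl on a saturated chain carbon bound to a saturated ring carbon. The step that the two limits leave unreadable from compound 3 to compound 1 cannot be sized because of the limit of < 3.5 mL/min/kg in this assay, at which 3 of the 3 values shown sit. Of compound 2 against compound 3 only this can be said: both values sit at the limit, and how the two cores differ is not broken down here.

Compound 4 `CC(=O)N[C@@H]1CCCc2c1cncc2N1C(=O)c2ccc(Cl)cc2[C@H]1C` has not yet been measured. It differs from compound 2 by hydrogen in place of methyl on a saturated chain carbon bound to a saturated ring carbon, the same change as from compound 3 to compound 1, so the change occurs twice among the compounds shown.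

For compound 4 the step expected from compound 2 is a step that the limit leaves unreadable from compound 2 to compound 4, resting on (the limit of < 3.5 mL/min/kg in this assay, at which 3 of the 3 values shown sit), where the same change in compound 1 left the read-out unchanged. Compound 4 is therefore expected at 2.5 mL/min/kg in this assay, between 1 mL/min/kg and 5 mL/min/kg, and most probably reported once more as a limit.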

Compound 4, clearance: < 3.5 mL/min/kg
Compound 4 was reported as a limit (the forecaster's own chance of this, stated with the estimate: 80%); the middle value does not contradict the limit.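

Compound 2 and compound 4 both stand as limits in this assay, so no new step can be read from this pair: the limit of < 3.5 mL/min/kg in this assay, at which 4 of the 4 values shown sit.

The compounds shown leave open the actual clearance of each of them, and with it whether the change from ethyl to methyl moves this read-out at all.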